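Turning the double bond of compound 2 from E to Z

This account rests on a few compounds, and the source may have more. Where it says the series, first, only, none or still open, it means among the compounds named here.

Among the compounds with values here, in a functional assay on HeLa cells (Homo sapiens) for inhibition (a higher number here means a weaker inhibitor, a lower number a stronger inhibitor), compound 2 (`COc1cc(/C=C/c2ccc(N(C)C)c(N)c2)cc(OC)c1OC`) gives 1520 nM and so far holds the only actual number in this small set. Compound 1 (`COc1cc(/C=C\c2ccc(N(C)C)c([N+](=O)[O-])c2)cc(OC)c1OC`) records > 5000 nM in this assay and that is a limit of the assay, not a number.

Within the data shown here, compound 3 (`COc1cc(/C=C\c2ccc(N(C)C)c(N)c2)cc(OC)c1OC`) is the geometric partner of compound 2 (the two compounds have the same atoms and bonds and differ only in configuration as drawn: 1 of 1 stereo elements differ; a double bond is drawn E in compound 2 and Z in compound 3), with the double bond drawn Z in place of E. No measured pair here isolates this change, so any forecast for it remains a judgement and needs wide bounds. A sizeable move toward stronger inhibition is nevertheless expected, and the estimated step of a 15-fold lower number from compound 2 to compound 3 (1.18 log units; beyond the scatter) would lie beyond the usual scatter. Compound 3 is estimated to give 100 nM with an expected range from 8 nM to 1500 nM in this assay once it is tested.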

Compound 3, half-maximal inhibitory concentration: 3 nM
Compound 3: the middle estimate sits 33-fold (1.52 log units) above what was measured, outside the stated range (below it).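

In this assay, the configuration of the double bond alone accounts for a 510-fold lower number from compound 2 to compound 3 (2.70 log units; beyond the scatter), and this large step can be assigned to that bond because nothing else changes: the fact that compounds 2 and 3 differ only in the configuration as drawn With the double bond drawn Z in both compounds, amino in place of nitro on an aromatic carbon gives an at least 1600-fold lower number from compound 1 to compound 3 (3.22 log units; beyond the scatter). The size of that step rests on the limit for compound 1, which is not a number: the limit of > 5000 nM in this assay, at which 1 of the 3 values shown sits.

The compounds shown set only nitro against amino on the Z double bond, so it remains open how a hydroxyl or an acetamide at that place would read in this assay. On these data alone, it also remains open whether the amino-for-nitro change would have a similar effect with the double bond drawn E.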